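The source may report more compounds than this note shows. Statements on the series, on what has been measured and on what is new or still open speak of the compounds shown alone.

In a functional assay on BGC-823 cells (Homo sapiens) for inhibition, read by MTT assay, with a stated time of 72 h (a higher number here means a weaker inhibitor, a lower number a stronger inhibitor), compound 1 `Cc1cc(N2CC[C@@H](C)[C@@H](N(C)c3ncnc4[nH]ccc34)C2)n2ncnc2n1` gives 67400 nM and compound 2 `Cc1cc(N2CC[C@@H](C)[C@@H](N(C)c3ncnc4[nH]ccc34)C2)n2nc(SCc3ccccc3Br)nc2n1` gives 81100 nM. These two numbers lie within the scatter of each other, so compound 2 stands level with compound 1. Compound 3 `Cc1nc2nc(SCc3ccc(Cl)cc3)nn2c(N2CC[C@@H](C)[C@@H](N(C)c3ncnc4[nH]ccc34)C2)c1C` gives > 100000 nM, which is a limit of the assay and not a number.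

Compound 4 `Cc1cc(N2CC[C@@H](C)[C@@H](N(C)c3ncnc4[nH]ccc34)C2)n2nc(SCCc3ccccc3)nc2n1` alters the side chain of compound 2: benzyl in place of 2-bromophenyl on a saturated chain carbon bound to a sulfur. In short, the (2-bromobenzyl)sulfanyl of compound 2 becomes phenethylsulfanyl in compound 4.

For the measured compounds named here, only one measured step bears on this side chain. Putting (2-bromobenzyl)sulfanyl in place of hydrogen on an aromatic carbon gave a 1.2-fold higher number from compound 1 to compound 2 (0.08 log units; within the scatter). Since adding the whole group moved the number so little, changing only its outer part is not expected to move it beyond the scatter in this assay.

The expected change is a 1.0-fold lower number from compound 2 to compound 4 (0.01 log units; within the scatter). For compound 4 the estimated value is 80000 nM, with an expected range of 45000 nM to 130000 nM.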

Compound 4, half-maximal inhibitory concentration: 28000 nM
Compound 4: the middle estimate sits 2.9-fold (0.46 log units) above what was measured; the measured number lies below the stated range.
By their numbers in this assay, from the lowest: compound 4; then compounds 1 and 2 (each within the scatter of the next). At a limit, above all of these: compound 3.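

In this assay, the side chain at this place can move the number beyond the scatter: going from (2-bromobenzyl)sulfanyl to phenethylsulfanyl gives a 2.9-fold lower number from compound 2 to compound 4 (0.46 log units; beyond the scatter). Phenethylsulfanyl also separates from plain hydrogen on the aromatic carbon, with a 2.4-fold lower number from compound 1 to compound 4 (0.38 log units; beyond the scatter), whereas (2-bromobenzyl)sulfanyl stayed within the scatter of hydrogen, so among these compounds the outer part of the group decides whether the number shifts at all. Nothing measured here gives a cause for this shift.

The step changes two things at once, the loss of the bromine and the longer chain to the phenyl ring, and the compounds shown leave open which one carries the shift. Also open, going by these compounds, is whether a longer chain still, such as phenylpropylsulfanyl, or an amine at the end of the chain would lower the number further.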